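A few compounds are considered here, and "the series" means these few. Any claim that something is new, unique, unknown or untested is made for them only; others in the source may bear on it.

Measured so far in a physicochemical assay for acid dissociation:
compound 1 `COc1ccc(F)cc1CNCCCNc1ccnc2cc(C3CCCCC3)ccc12` gives 9.47;
compound 2 `COc1cccc(CNCCCNc2ccnc3cc(Cc4ccccc4)ccc23)c1O` gives 9.47;
compound 3 `COc1cccc(CNCCCNc2ccnc3cc(Oc4ccc(F)cc4)ccc23)c1O` gives 9.28.

Compound 1 stands level with compound 2 at the digits shown, and the two together are the highest of the three numbers. Compound 3 sits lowest, yet its distance from compound 1 is within the scatter, so on this read-out the three compounds cannot be told apart.

The compound to be measured next is compound 4 `COc1ccc(F)cc1CNCCCNc1ccnc2cc(Cc3ccc(F)cc3)ccc12`. It differs from compound 1 in one place: 4-fluorobenzyl in place of cyclohexyl on an aromatic carbon. For the measured compounds named here, one measured step bears on this change, because it too exchanges the group on that same aromatic carbon of the shared core while everything else stays fixed: a number 0.19 log units lower from compound 2 to compound 3 (within the scatter). There, swapping one aromatic group for another left the acid dissociation constant unchanged beyond the scatter. Going by the values given here, with only this single comparison to go on, no step beyond the scatter is expected from trading cyclohexyl for 4-fluorobenzyl.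

Compound 4 is therefore estimated at 9.45, with a range from 9.15 to 9.75. The expected step is a number 0.02 log units lower from compound 1 to compound 4 (within the scatter), which is within the scatter.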

Compound 4, acid dissociation constant: 9.47
Compound 4: middle estimate off by 0.02 log units, on the low side, within the range that was stated.
By their numbers in this assay, from the lowest: compounds 3, 1, 2 and 4 (each within the scatter of the next).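

In this assay, exchanging cyclohexyl for 4-fluorobenzyl on this aromatic carbon of the shared core gives no change at the digits printed from compound 1 to compound 4 (within the scatter). A non-aromatic ring of carbon only thus gives way to an aromatic ring, and a group of 6 heavy atoms to one of 8 that includes fluorine, without the read-out moving beyond the scatter, whereas the earlier step at this position, a number 0.19 log units lower from compound 2 to compound 3 (within the scatter), exchanged one group bearing an aromatic ring for another. Across these two steps, which start from different compounds, no exchange at this position stands out from the scatter, and nothing measured here speaks to the reason for that.

On these data alone, all the groups compared at this position have no hydrogen-bond donors, so it remains open whether an amine or a carboxylic acid on this aromatic carbon would shift the number beyond the scatter. It is also open whether a change elsewhere in the molecule, such as a longer chain in place of the one shared by these compounds, would move the read-out, since every single-place step shown concerns this one aromatic carbon.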